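The source may hold more compounds than are shown below. What is called first, only, known or untested is meant among the compounds shown, and "the series" means these compounds.

Measured so far: compound 1 `Cc1ccc(Oc2cc(C(O)CC3CCCCN3)c3ccccc3n2)cc1`, 2.69; compound 2 `CC(C)(C)c1cc(C(O)CC2CCCCN2)c2cc(Cl)ccc2n1`, 2.74; compound 3 `Cc1ccc(Oc2cc(C(O)CC3CCCCN3)c3cc(Cl)ccc3n2)cc1`, 3.4.

In a physicochemical assay for lipophilicity (on this read-out higher numbers stand for higher lipophilicity and lower numbers for lower lipophilicity), compound 1 stands lowest of the three numbers; compound 2 lies within the scatter of it, while the gap to compound 3 is a number 0.71 log units higher from compound 1 to compound 3 (beyond the scatter). Compound 4 `CC(C)c1cc(C(O)CC2CCCCN2)c2ccccc2n1` differs from compound 1 in one place: isopropyl in place of 4-methylphenoxy on an aromatic carbon. The measured step that bears on this is a number 0.66 log units higher from compound 2 to compound 3 (beyond the scatter), where 4-methylphenoxy likewise sits on an aromatic carbon of the shared core; the reverse exchange should therefore lower the value by a modest amount. That step concerned tert-butyl rather than isopropyl, so it serves as a guide only. Compound 4 is expected to give 1.85, range 1.3 to 2.4, an estimated step of a number 0.84 log units lower from compound 1 to compound 4 (beyond the scatter) beyond the scatter.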

Compound 4, partition coefficient: 1.58
The estimate for compound 4 lay 0.27 log units above the measured number, and the stated range covers the measured number.
By their numbers in this assay, from the lowest: compound 4; then compounds 1 and 2 (each within the scatter of the next); then compound 3.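

In this assay, isopropyl in place of 4-methylphenoxy, next to the ring nitrogen, gives a number 1.11 log units lower from compound 1 to compound 4 (beyond the scatter) and counts as large, whereas a number 0.66 log units higher from compound 2 to compound 3 (beyond the scatter) on the chloro-bearing core was modest. In both pairs, the compound carrying 4-methylphenoxy has the higher number, with either alkyl group and with or without chloro. No measurement given here accounts for the size of the new step.

On these data alone, since tert-butyl and isopropyl sit on different cores, whether the size of the step follows the alkyl group or the chloro remains open. As far as these compounds go, how an amine or a carboxylic acid at this position would stand in this assay is also open.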